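Fluorine on the aryl of a sulfone acid series

The source may hold more compounds than are shown below. What is called first, only, known or untested is meant among the compounds shown, and "the series" means these compounds.

Measured compounds:
- compound 1, `COC(=O)C(Nc1cc(CS(=O)(=O)/C=C/c2c(OC)cc(OC)cc2OC)ccc1OC)c1ccccc1`: 75 nM
- compound 2, `COC(=O)C(Nc1cc(CS(=O)(=O)/C=C/c2c(OC)cc(OC)cc2OC)ccc1OC)c1ccc(F)cc1`: 300 nM
- compound 3, `COc1cc(OC)c(/C=C/S(=O)(=O)Cc2ccc(OC)c(NC(C(=O)O)c3ccccc3)c2)c(OC)c1`: 20 nM

Three compounds were tested in a functional assay on DU-145 cells (Homo sapiens) for cytotoxicity, read by trypan blue exclusion, with a stated time of 96 h; on this read-out higher numbers stand for weaker inhibition and lower numbers for stronger inhibition. Compound 1 `COC(=O)C(Nc1cc(CS(=O)(=O)/C=C/c2c(OC)cc(OC)cc2OC)ccc1OC)c1ccccc1` gives 75 nM in this assay. Its partner compound 2 `COC(=O)C(Nc1cc(CS(=O)(=O)/C=C/c2c(OC)cc(OC)cc2OC)ccc1OC)c1ccc(F)cc1` carries the change fluoro in place of hydrogen on an aromatic carbon and gives 300 nM; the step of a 4.0-fold higher number from compound 1 to compound 2 (0.60 log units; beyond the scatter) is one in the weaker direction. Compound 3 `COc1cc(OC)c(/C=C/S(=O)(=O)Cc2ccc(OC)c(NC(C(=O)O)c3ccccc3)c2)c(OC)c1` differs from compound 1 by hydrogen in place of methyl on an oxygen next to a carbonyl group. In this assay compound 3 gives 20 nM, the step being a 3.8-fold lower number from compound 1 to compound 3 (0.57 log units; beyond the scatter); compared with compound 2, the step is a 15-fold lower number from compound 2 to compound 3 (1.18 log units; beyond the scatter).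

Compound 4 `COc1cc(OC)c(/C=C/S(=O)(=O)Cc2ccc(OC)c(NC(C(=O)O)c3ccc(F)cc3)c2)c(OC)c1` has not yet been measured. It differs from compound 3 by fluoro in place of hydrogen on an aromatic carbon, the same change as made from compound 1 to compound 2, with the place described in identical words. Because the earlier step was a 4.0-fold higher number from compound 1 to compound 2 (0.60 log units; beyond the scatter), a step of similar size in the weaker direction is expected from compound 3 to compound 4, namely a 4.0-fold higher number from compound 3 to compound 4 (0.60 log units; beyond the scatter). Compound 4 is therefore estimated to give 80 nM in this assay, with an expected range from 35 nM to 180 nM.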

Compound 4, half-maximal inhibitory concentration: 150 nM
Compound 4: the middle estimate sits 1.9-fold (0.27 log units) below what was measured; measured number inside the range.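

In this assay, fluoro in place of hydrogen on the aromatic carbon again gave a step in the weaker direction, a 7.5-fold higher number from compound 3 to compound 4 (0.88 log units; beyond the scatter), and its size agrees with that of the earlier step on the core of compound 1: the same change on two cores in this assay, a 4.0-fold higher number (0.60 log units; beyond the scatter) from compound 1 to compound 2 and a 7.5-fold higher number (0.88 log units; beyond the scatter) from compound 3 to compound 4, 1.9-fold (0.27 log units) apart, within the scatter of two such steps. Hydrogen in place of methyl on the oxygen next to a carbonyl group gave a 2.0-fold lower number from compound 2 to compound 4 (0.30 log units; within the scatter), and this step does not differ from its earlier counterpart beyond the scatter: the same change on two cores in this assay, a 3.8-fold lower number (0.57 log units; beyond the scatter) from compound 1 to compound 3 and a 2.0-fold lower number (0.30 log units; within the scatter) from compound 2 to compound 4, 1.9-fold (0.27 log units) apart, within the scatter of two such steps. Both changes therefore carried over between these two cores, and the two changes together left a 2.0-fold higher number from compound 1 to compound 4 (0.30 log units; within the scatter), but two pairs per change do not show that either would carry to any other core, nor do they explain why the steps occur.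

As far as these compounds go, it remains open how chloro, methoxy or trifluoromethyl in place of that fluoro would behave on either core. Also open, from the compounds shown here alone, is what a primary amide in place of the carboxylic acid would give.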